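The source may hold more compounds than are shown below. What is called first, only, known or untested is meant among the compounds shown, and "the series" means these compounds.

Measured so far in an assay on CHO cells for antagonist activity at transient receptor potential cation channel subfamily V member 1 (Homo sapiens), read by FLIPR; on this read-out lower numbers stand for stronger inhibition and higher numbers for weaker inhibition:

Compound 1 `CCC(C(=O)NCc1ccc(C(F)(F)F)nc1N1CCC(C)CC1)c1ccc(NS(C)(=O)=O)c(F)c1`: 1.6 nM
Compound 2 `CS(=O)(=O)Nc1ccc(C(C(=O)NCc2ccc(C(F)(F)F)nc2SC2CCCCC2)c2cccc(F)c2)cc1F`: 48.7 nM
Compound 3 `CS(=O)(=O)Nc1ccc(C(Cc2ccc(F)cc2)C(=O)NCc2ccc(C(F)(F)F)nc2SC2CCCCC2)cc1F`: "active" (no number reported)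

Compound 1 stands lowest of the two numbers in this assay. Compound 2, the nearest, is higher by a margin well beyond the usual scatter, so compound 1 is clearly the stronger of the two. Compound 3 carries no number and only shows that a compound of this type can remain active. Among the measured compounds shown here, compound 2 and compound 3 each differ from compound 1 in more than one place, so no single step between measured compounds can be drawn from them.

Compound 4 `Cc1ccc(CC(C(=O)NCc2ccc(C(F)(F)F)nc2N2CCC(C)CC2)c2ccc(NS(C)(=O)=O)c(F)c2)cc1` has not been measured. It differs from compound 1 in one place: 4-methylphenyl in place of methyl on a saturated chain carbon, two bonds along the chain from an aromatic carbon and a carbonyl carbon. Nothing in the data shows a change at this saturated chain carbon in isolation, so the expected step rests on compound 1 alone as the anchor. A modest weakening is expected, a step from compound 1 to compound 4 of about a 3.1-fold higher number from compound 1 to compound 4 (0.49 log units; beyond the scatter), at or just beyond the edge of the scatter, rather than a large loss. For compound 4 in this assay the estimate is 5 nM, with a range of 1.5 nM to 20 nM.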

Compound 4, inhibition constant: "active" (no number reported)
Nothing numeric was reported for compound 4; there is nothing to compare the estimate with.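

In this assay compound 4 gives "active" (no number reported) and so yields no readable step from compound 1. The compounds shown leave open how far 4-methylbenzyl in place of ethyl moves the number, though compound 4 remains active. No supporting measurement bears on this result.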